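A few compounds are considered here, and "the series" means these few. Any claim that something is new, unique, unknown or untested is made for them only; others in the source may bear on it.

Compound 1 `Cc1cccc(C#CCNc2cccc(Cl)c2)n1` and compound 2 `Cc1cccc(C#CCNc2ccccc2)n1` share one core; compound 1 carries a chloro group on its aromatic ring where compound 2 carries a hydrogen. In a functional assay for inhibition of metabotropic glutamate receptor 5 (Homo sapiens), read by FLIPR and calcium flux (on this read-out higher numbers stand for weaker inhibition and lower numbers for stronger inhibition), compound 1 gives 174 nM, and compound 2 gives 223 nM. The step of a 1.3-fold higher number from compound 1 to compound 2 (0.11 log units; within the scatter) is small, so the two numbers cannot be told apart. Among the compounds with values here, compound 1 has the lowest of the two numbers measured so far, but with compound 2 this close the lead means little.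

Compound 3 `Cc1cccc(C#CC(C)Nc2cccc(Cl)c2)n1` keeps the chloro group of compound 1 and differs from it in one place: methyl in place of hydrogen on a saturated chain carbon bound to a nitrogen on an aromatic ring and a triple-bonded carbon. Within the data shown here, no measured step touches this chain carbon; the single measured step concerns the aromatic ring and lay within the scatter. There is therefore no measured guide to this change, and the expectation rests on the shared core alone. For compound 3 the expected step is a 1.1-fold higher number from compound 1 to compound 3 (0.06 log units; within the scatter), nothing beyond the scatter. Compound 3 is estimated to give 200 nM in this assay, within a range from 70 nM to 600 nM.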

Compound 3, half-maximal inhibitory concentration: 709 nM
Estimate against measurement, compound 3: 3.5-fold (0.55 log units) below, outside the stated range (above it).
By their numbers in this assay, from the lowest: compounds 1 and 2 (each within the scatter of the next); then compound 3.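

The saturated chain carbon bound to a nitrogen on an aromatic ring and a triple-bonded carbon now has its first measured step, and it is a real one: in this assay, methyl in place of hydrogen gives a 4.1-fold higher number from compound 1 to compound 3 (0.61 log units; beyond the scatter) and so weaker inhibition. The earlier change on the aromatic ring, hydrogen in place of chloro, gave a 1.3-fold higher number from compound 1 to compound 2 (0.11 log units; within the scatter) and could not be told from noise, whereas this change of a single carbon atom on the chain lies beyond the scatter, which shows that this position does not tolerate every change without a loss. Nothing available here says why the methyl has this effect.

The compounds shown give only one substituent at this chain carbon, so it remains open whether an ethyl group, a longer chain or a hydroxyl group there would give a higher number, a similar one or a lower one. As far as these compounds go, it is also open whether methyl at this carbon would give a step of similar size on the core of compound 2, which has hydrogen in place of chloro on the aromatic ring.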